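The source may report more compounds than this note shows. Statements on the series, on what has been measured and on what is new or still open speak of the compounds shown alone.

In an ADME assay on HFF cells (Homo sapiens) for cytotoxicity, with a stated time of 8 days (a lower number here means that less compound is tolerated, a higher number that more compound is tolerated), compound 3, `CC(C)CNc1nc(N)nc2c1ncn2/C=C1/CC1(CO)CO`, gives > 300000 nM, which is a limit of the assay and not a number. Compound 1, `CCCCCCCCSc1nc(N)nc2c1ncn2/C=C1/CC1(CO)CO`, gives > 300000 nM in this assay, again a limit rather than a number. Compound 2, `CSc1nc(N)nc2c1ncn2/C=C1/CC1(CO)CO`, gives > 300000 nM in this assay, also a limit. All three values therefore sit at the limit of > 300000 nM in this assay, at which 3 of the 3 values shown sit, and for that reason none of the measured steps can be read: a step that the two limits leave unreadable from compound 1 to compound 2, a step that the two limits leave unreadable from compound 1 to compound 3 and a step that the two limits leave unreadable from compound 2 to compound 3 are all of unreadable size.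

Compound 4, `Nc1nc(SCc2ccccc2)c2ncn(/C=C3/CC3(CO)CO)c2n1`, differs from compound 3 in one place: benzylsulfanyl in place of isobutylamino on an aromatic carbon. Going by the values given here, the steps that bear on this change are those that also replace the group on that aromatic carbon, from compound 1 to compound 3 and from compound 2 to compound 3, and both are unreadable because the two values at either end sit at the limit of > 300000 nM in this assay, at which 3 of the 3 values shown sit. Each of the two sulfanyl groups already seen at that carbon left compound 1 and compound 2 at the limit, so no step beyond the scatter is expected in this assay from compound 3 to compound 4: a step that the limit leaves unreadable from compound 3 to compound 4. Compound 4 is estimated at 400000 nM, within 100000 nM to 1500000 nM, most likely reported again only as a limit.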

Compound 4, half-maximal cytotoxic concentration: > 300000 nM
Compound 4: no number, only a limit; the forecaster's own chance of this, stated with the estimate: 85%; the middle value lies beyond the limit too.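

In this assay the steps from compound 1, compound 2 and compound 3 to compound 4 cannot be read, because all four values are limits and not numbers: the limit of > 300000 nM in this assay, at which 4 of the 4 values shown sit.

The compounds shown leave open where the half-maximal cytotoxic concentration of any of them lies, and whether the group on that aromatic carbon changes it.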